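One swap on compound 1, its solubility still open

The source may report more compounds than this note shows. Statements on the series, on what has been measured and on what is new or still open speak of the compounds shown alone.

Solubility tells how much of a compound stays dissolved, and here it has been measured for only two compounds. In a physicochemical assay for solubility, read by HPLC, using the shake flask method, in phosphate buffer, measured as kinetic solubility, with a stated time of 20 h, at pH 6.5 (on this read-out lower numbers stand for lower solubility and higher numbers for higher solubility), compound 1 (`Fc1ccc(Nc2cc3[nH]c(Nc4cc(N5CCNCC5)ccn4)nc3cn2)cc1C(F)(F)F`) gives 95000 nM while compound 2 (`FC1(F)CC(Nc2cc3[nH]c(Nc4ccc(N5CCN(CC6CC6)CC5)cn4)nc3cn2)C1`) gives 190000 nM and these two numbers lie within the usual scatter of repeated measurements. Within the data shown here, compound 1 therefore stands level with the only other compound measured, and neither can be ranked over the other.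

Compound 3 (`O=C(c1ccnc(Nc2nc3cnc(Nc4ccc(F)c(C(F)(F)F)c4)cc3[nH]2)c1)N1CCN(C2CC2)CC1`) keeps the rest of compound 1 and changes one group. It has (4-cyclopropylpiperazin-1-yl)carbonyl in place of piperazin-1-yl on an aromatic carbon, at the spot opposite the ring nitrogen. Among the measured compounds shown here, no two measured compounds differ in one place only, so the data offer no direct guide to this swap, and what follows is a judgement.

With compound 1 at 95000 nM as the anchor, the step expected in this assay is a 3.2-fold lower number from compound 1 to compound 3 (0.50 log units; beyond the scatter) and this estimated drop would lie beyond the scatter. For compound 3 the estimated value is 30000 nM within an expected range of 6000 nM to 120000 nM (still to be tested).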

Compound 3, solubility: < 5000 nM
Compound 3 was reported as a limit; the forecaster's own chance of this, stated with the estimate: 10%; middle value at least 6.0-fold (0.77 log units) away from the limit.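

In this assay compound 3 gives < 5000 nM and this is a limit of the assay, not a number: the limit of < 5000 nM in this assay, at which 1 of the 3 values shown sits.

This is the first change in one place only among the compounds shown, and it gives an at least 19-fold lower number from compound 1 to compound 3 (1.27 log units; beyond the scatter) in a direction and of a size that the earlier pair of compounds could not reveal, so what sits on this aromatic carbon, opposite the ring nitrogen, clearly matters for how much compound stays dissolved. The swap changes several things at once: the hydrogen-bond donor of piperazin-1-yl is gone, and a carbonyl and a three-membered ring of carbon only come in, so the step belongs to the whole group and not to any one of these parts.

The compounds shown do not tell whether the carbonyl or the cyclopropyl ring carries the step, and the true size of the step stays open while compound 3 stands at a limit. Also open, as far as these compounds go, is how the same spot would respond to a simple amine, a carboxylic acid or a morpholine ring joined directly to the aromatic carbon.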